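The source may report more compounds than this note shows. Statements on the series, on what has been measured and on what is new or still open speak of the compounds shown alone.

Measured so far in a functional assay on HepG2 cells (Homo sapiens) for cytotoxicity, read by MTT assay, with a stated time of 3 days; a higher number here means a weaker inhibitor, a lower number a stronger inhibitor:
compound 1 `C#Cc1cccc(Nc2ncnc3ccccc23)c1` gives 4160 nM.
compound 2 `O=[N+]([O-])c1ccccc1-n1cc(-c2cccc(Nc3ncnc4ccccc34)c2)nn1` gives 4640 nM.
compound 3 `O=[N+]([O-])c1cccc(-n2cc(-c3cccc(Nc4ncnc5ccccc45)c3)nn2)c1` gives 287000 nM.

Compound 3 carries the highest number of the three, beyond the scatter from compound 2 and from compound 1. Compound 1 and compound 2 lie within the scatter of each other, so the five-membered aromatic ring with 3 nitrogen and its 2-nitrophenyl add nothing that can be read as a change. Among the measured compounds shown here, the one step that bears on the next change is a 62-fold higher number from compound 2 to compound 3 (1.79 log units; beyond the scatter): exchanging which nitrophenyl sits on that aromatic nitrogen shifted the number by a large amount. Compound 4 `O=[N+]([O-])c1ccc(-n2cc(-c3cccc(Nc4ncnc5ccccc45)c3)nn2)cc1` differs from compound 3 by 4-nitrophenyl in place of 3-nitrophenyl on an aromatic nitrogen. For the measured compounds named here, no measured compound carries 4-nitrophenyl, so the direction rests only on the observation that compound 3 sits far above the other two and that the nitrophenyl exchange has already proven capable of a large shift. A lower number than compound 3 is expected, of a size well short of the earlier step, with a wide range. Compound 4 is therefore expected at 40000 nM, within 4000 nM to 300000 nM. The expected step is a 7.2-fold lower number from compound 3 to compound 4 (0.86 log units; beyond the scatter).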

Compound 4, half-maximal inhibitory concentration: 8110 nM
Compound 4: middle estimate off by 4.9-fold (0.69 log units), on the high side; the measured number falls inside the stated range.
By their numbers in this assay, from the lowest: compounds 1, 2 and 4 (each within the scatter of the next); then compound 3.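

In this assay, 4-nitrophenyl in place of 3-nitrophenyl on the aromatic nitrogen gives a large step back down (a 35-fold lower number from compound 3 to compound 4 (1.55 log units; beyond the scatter)), so the earlier rise is not shared by every change away from 2-nitrophenyl. 4-nitrophenyl in place of 2-nitrophenyl gives a step within the scatter (a 1.7-fold higher number from compound 2 to compound 4 (0.24 log units; within the scatter)), which leaves compound 3 alone apart from compound 2 and compound 4, although all three carry the same atoms joined differently. Nothing available explains why the 3-nitrophenyl arrangement stands apart.

Still open, from the compounds shown here alone, is whether the high number of compound 3 depends on the nitro group itself or would appear with other groups on that phenyl ring. An aminophenyl or a carboxyphenyl in place of 3-nitrophenyl, and a plain phenyl on the same aromatic nitrogen, would bear on this.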